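Swapping the Aryl Group: Expected Cytotoxicity of Compound 4

The compounds below may be only part of what the source reports. "The series", "measured", "known", "first", "only" and "open" are said of these compounds alone.

Compound 1 `CS(=O)(=O)c1ccc(Cc2nnc3n2N=C(c2ccccc2)CS3)cc1` gives 55.5% in a functional assay on HT-29 cells (Homo sapiens) for cytotoxicity, read by MTT assay, with a stated time of 48 h, tested at 100 uM; a lower number here means a weaker effect, a higher number a stronger effect of the compound at the concentration tested.
Compound 2 `CS(=O)(=O)c1ccc(Cc2nnc3n2N=C(c2ccc(-c4ccccc4)cc2)CS3)cc1` gives 74.8% in this assay.
Compound 3 `CS(=O)(=O)c1ccc(Cc2nnc3n2N=C(c2ccc(Cl)cc2Cl)CS3)cc1` gives 31% in this assay.

All three share one core and differ only in the aryl group on the carbon with a double bond to nitrogen. Compound 3 stands lowest of the three numbers, with compound 1 nearest and compound 2 furthest away, both gaps beyond the scatter.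

Compound 4 `Cc1ccc(C2=Nn3c(Cc4ccc(S(C)(=O)=O)cc4)nnc3SC2)cc1` differs from compound 3 by 4-methylphenyl in place of 2,4-dichlorophenyl on a carbon with a double bond to nitrogen. For the measured compounds named here, two measured steps bear on this change. The first is a number 24.5 percentage points lower from compound 1 to compound 3 (beyond the scatter), so taking the 2,4-dichlorophenyl away again is expected to recover roughly that loss. The second is a number 19.3 percentage points higher from compound 1 to compound 2 (beyond the scatter), where a group added to the plain phenyl raised the read-out; a methyl is a smaller addition than a phenyl, so only a small further gain, if any, is expected from it.

Taken together, the step of a number 25 percentage points higher from compound 3 to compound 4 (beyond the scatter) is expected, upward and beyond the scatter. Compound 4 is therefore estimated at 56%, with a likely range from 38% to 74%.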

Compound 4, a percentage reported as activity, at one concentration (the size of the read-out at that concentration, not a potency): 38.5%
Beside the measured number, compound 4's estimate is 17.5 percentage points above it, within the range that was stated.
By their numbers in this assay, from the lowest: compounds 3 and 4 (each within the scatter of the next); then compound 1; then compound 2.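

In this assay, the step of a number 7.5 percentage points higher from compound 3 to compound 4 (within the scatter) shows that 4-methylphenyl and 2,4-dichlorophenyl cannot be told apart at this position. The methyl also shows that adding to the plain phenyl does not always raise the number: swapping hydrogen for methyl on the aromatic carbon is a number 17 percentage points lower from compound 1 to compound 4 (beyond the scatter), whereas the phenyl added at that same carbon in compound 2 went the other way. The two additions therefore lie far apart, with a number 36.3 percentage points lower from compound 2 to compound 4 (beyond the scatter) as the change from phenyl to methyl.

From the compounds shown here alone, what an amine, a carboxylic acid or a longer chain such as propyl on that aromatic carbon would do remains open. No available evidence explains why methyl and phenyl on the same carbon take the number in opposite directions.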